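The compounds below may be only part of what the source reports. "The series", "measured", "known", "first", "only" and "open" are said of these compounds alone.

In an assay on HEK293 cells for negative allosteric modulation of metabotropic glutamate receptor 5 (Homo sapiens), read by FLIPR, with a stated time of 1 h (on this read-out higher numbers stand for weaker inhibition and lower numbers for stronger inhibition), compound 3 `CCC(=O)N1CCc2nc(C#Cc3ccccc3)sc2C1` gives 38 nM, the lowest of the two numbers shown; the nearest is compound 2 `CC(=O)N1CCc2nc(C#Cc3ccccc3)sc2C1`, which in this assay gives 90 nM. In this assay compound 1 `C(#Cc1nc2c(s1)CN(C1CCCCC1)CC2)c1ccccc1` reports > 10000 nM, a limit of the assay and not a number, (the limit of > 10000 nM in this assay, at which 1 of the 3 values shown sits). Compound 4 `CC1CC1C(=O)N1CCc2nc(C#Cc3ccccc3)sc2C1` is not yet measured; it differs from compound 3 in 2-methylcyclopropyl in place of ethyl on a carbonyl carbon, on a carbonyl carbon whose other neighbour is the amide-type nitrogen in a ring.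

Of the measured steps, an at least 110-fold lower number from compound 1 to compound 2 (2.04 log units; beyond the scatter) and an at least 260-fold lower number from compound 1 to compound 3 (2.42 log units; beyond the scatter) concern the exchange of cyclohexyl for an acyl group and are large, but bear only loosely on the present change. Closer is a 2.4-fold lower number from compound 2 to compound 3 (0.37 log units; beyond the scatter), a modest step from extending the acyl chain by one carbon. The move to compound 4 extends the acyl further, from ethyl to 2-methylcyclopropyl, so a modest step in this assay, toward a lower number or none beyond the scatter, is expected.

Compound 4 is estimated at 25 nM, between 8 nM and 80 nM, which is an expected 1.5-fold lower number from compound 3 to compound 4 (0.18 log units; within the scatter).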

Compound 4, half-maximal inhibitory concentration: > 10000 nM
Compound 4: only a limit was reported; the forecaster's own chance of this, stated with the estimate: 3%; middle value at least 400-fold (2.60 log units) away from the limit.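

Compound 4 is reported only as a limit of the assay: the limit of > 10000 nM in this assay, at which 2 of the 4 values shown sit.

On this carbonyl carbon the acyl group is far less forgiving than the earlier pair suggested: in this assay, a 2.4-fold lower number from compound 2 to compound 3 (0.37 log units; beyond the scatter) gave no hint of an at least 260-fold higher number from compound 3 to compound 4 (2.42 log units; beyond the scatter), or of an at least 110-fold higher number from compound 2 to compound 4 (2.04 log units; beyond the scatter). Replacing ethyl with 2-methylcyclopropyl, which adds a three-membered ring, therefore reverses the earlier trend within the acyl series, and the shared core with an acyl group does not by itself secure a low number. The step from compound 1 to compound 4 cannot be read, as both values are limits.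

As far as these compounds go, it remains open whether the jump follows the ring, its methyl or the carbon count alone. A plain cyclopropyl or a butyl chain on the same carbonyl carbon would separate these.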